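A Cyano Group Enters the Pyrazole Urea

The source may report more compounds than this note shows. Statements on the series, on what has been measured and on what is new or still open speak of the compounds shown alone.

Compound 2 `O=C(NCc1ccc(OC(c2ccccc2)c2ccccc2)cc1)n1cccn1` gives in an assay on membranes from brain for binding affinity to Monoglyceride lipase (Mus musculus), read by fluorescence, with stated times of 1 h and 30 min (on this read-out lower numbers stand for stronger inhibition and higher numbers for weaker inhibition), a reading of > 100000 nM, which is a limit of the assay and not a number (the limit of > 100000 nM in this assay, at which 1 of the 2 values shown sits). Differing from compound 2 in two places, compound 1 `N#Cc1cnn(C(=O)NCc2ccc(OCc3ccccc3)cc2)c1` gives in this assay a value of 100 nM. Compound 3 `N#Cc1cnn(C(=O)NCc2ccc(OC(c3ccccc3)c3ccccc3)cc2)c1` arises from compound 2 by cyano in place of hydrogen on an aromatic carbon. For the measured compounds named here, no single-point step is measured, yet the two values of compound 2 and compound 1 point to a large move toward stronger inhibition. Compound 3 is therefore expected to give about 150 nM, within 30 nM to 1000 nM. The expected step is an at least 660-fold lower number from compound 2 to compound 3 (2.82 log units; beyond the scatter).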

Compound 3, half-maximal inhibitory concentration: > 100000 nM
Compound 3 ended at the assay's limit; the forecaster's own chance of this, stated with the estimate: 10%; at least 660-fold (2.82 log units) between middle value and limit.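

Phenyl in place of hydrogen on the saturated chain carbon gives an at least 1000-fold higher number from compound 1 to compound 3 (3.00 log units; beyond the scatter) in this assay, so this one change removes the inhibition seen with the 4-cyano-1H-pyrazol-1-yl group in compound 1. The 4-cyano-1H-pyrazol-1-yl group therefore does not bring inhibition with it when the second phenyl is present. The effect of the cyano group itself cannot be read, since compound 2 and compound 3 both stand at a limit of the assay: the limit of > 100000 nM in this assay, at which 2 of the 3 values shown sit.

Open remains what the cyano group contributes without the second phenyl. Also open, on these data alone, is whether a methyl group on that saturated chain carbon would keep the inhibition of compound 1.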